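This account rests on a few compounds, and the source may have more. Where it says the series, first, only, none or still open, it means among the compounds named here.

Measured so far in an ADME assay on the whole organism with Oryza sativa as the target, tested at 1 uM; a higher number here means a weaker effect of the compound at the concentration tested, a lower number a stronger effect:

compound 1 `CCc1cccc(NC(=O)N[C@H](C)c2ccccc2)c1` gives 71%
compound 2 `CCc1cccc(NC(=O)N[C@@H](C)c2ccccc2)c1` gives 94%
compound 3 `C[C@@H](NC(=O)Nc1ccccc1C(C)(C)C)c1ccccc1` gives 95%

Compound 2 stands second highest of the three numbers in this assay; compound 3 sits within the scatter of it, while compound 1 lies well below it, a number 23 percentage points higher from compound 1 to compound 2 (beyond the scatter). That single step is the only one on record, and it rests on (the fact that compounds 1 and 2 differ only in the configuration as drawn), so it tells nothing about a change of substituent.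

The next compound, compound 4 `CCOC(=O)c1cccc(NC(=O)N[C@@H](C)c2ccccc2)c1`, differs from compound 2 by ethoxycarbonyl in place of ethyl on an aromatic carbon. Among the measured compounds shown here, no measured step bears on this change; the expectation can only start from compound 2 and carry a wide range. The expected step is a number 6 percentage points lower from compound 2 to compound 4 (within the scatter), that is, none beyond the scatter. Compound 4 is therefore estimated at 88%, within 62% to 100%.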

Compound 4, a percentage reported as activity, at one concentration (the size of the read-out at that concentration, not a potency): 99%
Compound 4: the middle estimate sits 11 percentage points below what was measured; the measured number falls inside the stated range.
By their numbers in this assay, from the lowest: compound 1; then compounds 2, 3 and 4 (each within the scatter of the next).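

In this assay the exchange of ethyl for ethoxycarbonyl on this aromatic carbon gives a number 5 percentage points higher from compound 2 to compound 4 (within the scatter) and so brings no stronger effect. With the configuration of compound 2, this place meta to a large group thus takes a larger group carrying hydrogen-bond acceptors without a step beyond the scatter. Nothing on record bears on why this exchange gives so small a step.

Still open, as far as these compounds go, is whether ethoxycarbonyl gives the same result in the configuration of compound 1. Also open, from the compounds shown here alone, is whether a carboxylic acid or an amine at this place gives a step beyond the scatter.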